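This account rests on a few compounds, and the source may have more. Where it says the series, first, only, none or still open, it means among the compounds named here.

Of the compounds shown here, three of one shared core have been measured in a functional assay on the whole organism (artery, strain albino) with Rattus norvegicus as the target, with a stated time of 180 min, at a dose of 10 mg/kg by the oral route; on this read-out higher numbers stand for more inhibition at the one dose given (going by the name of the read-out) and lower numbers for less inhibition. Compound 1 `COc1ccc(C2N=C(SCc3ccc(Cl)cc3)NC(C)=C2C(=O)Nc2ccc(Br)cc2)cc1` gives 22.7% in this assay. Compound 2 `COc1ccc(C2N=C(SCc3ccc(F)cc3)NC(C)=C2C(=O)Nc2ccc(Br)cc2)cc1` differs from compound 1 by fluoro in place of chloro on an aromatic carbon. In this assay compound 2 gives 17%, so that a number 5.7 percentage points lower from compound 1 to compound 2 (within the scatter). Compound 3 `CC1=C(C(=O)Nc2ccc([N+](=O)[O-])cc2)C(c2ccc(Br)cc2)N=C(SCc2ccc(Cl)cc2)N1` carries a core that differs from that of compound 1, and the difference between the two cores is not broken down here; in this assay compound 3 gives 19.1%, a number that sits near those of compound 1 and compound 2, all three within the scatter of one another.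

Compound 4 `CC1=C(C(=O)Nc2ccc([N+](=O)[O-])cc2)C(c2ccc(Br)cc2)N=C(SCc2ccc(F)cc2)N1` has not been measured. It differs from compound 3 by fluoro in place of chloro on an aromatic carbon, the same change that leads from compound 1 to compound 2, at a place described in the same words. Because the measured step of a number 5.7 percentage points lower from compound 1 to compound 2 (within the scatter) lay within the scatter, the expected step from compound 3 to compound 4 in this assay is of similar size, namely a number 5.1 percentage points lower from compound 3 to compound 4 (within the scatter). Compound 4 is therefore estimated to give 14% in this assay, with a range from 4% to 24%.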

Compound 4, a percentage reported as inhibition, in the whole organism at one dose (the size of the read-out at that dose, not a potency): 17.5%
Beside the measured number, compound 4's estimate is 3.5 percentage points below it, within the range that was stated.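

In this assay the change from chloro to fluoro comes out as a number 1.6 percentage points lower from compound 3 to compound 4 (within the scatter) on the core of compound 3, and set beside the step on the core of compound 1, the two steps agree: the same change on two cores in this assay, a number 5.7 percentage points lower (within the scatter) from compound 1 to compound 2 and a number 1.6 percentage points lower (within the scatter) from compound 3 to compound 4, 4.1 percentage points apart, within the scatter of two such steps.

On these two cores, then, the change carries over in the sense that neither step stands clear of the scatter, and the chloro and fluoro members of each pair cannot be told apart on this read-out. This does not show that the change would behave the same way on any other core, and two pairs read at a single oral dose cannot fix a direction for the change or tell whether the core alters its size.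

The compounds shown leave open what a nitrile or a trifluoromethyl group would give in place of the halogen. They also leave open whether an amine or a longer chain in place of the (4-fluorobenzyl)sulfanyl group would move the read-out beyond the scatter.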